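The source may hold more compounds than are shown below. What is called first, only, known or untested is meant among the compounds shown, and "the series" means these compounds.

Compound 3 `Nc1ccccc1NC(=O)c1ccc(Cn2cnc3c(NCc4ccccc4)nc(Cl)nc32)cc1` stands lowest of the three compounds measured in a functional assay on HepG2 cells (Homo sapiens) for antiproliferative activity, read by CCK-8 assay, with a stated time of 72 h, tested at 2 uM; a higher number here means a stronger effect of the compound at the concentration tested, a lower number a weaker effect: in this assay compound 3 gives 7.55%, while compound 1 `Cc1ccc(Nc2nc(Cl)nc3c2ncn3Cc2ccc(C(=O)Nc3ccccc3N)cc2)cc1` gives 76.2% and compound 2 `Nc1ccccc1NC(=O)/C=C/c1ccc(Cn2cnc3c(Nc4cccc(Cl)c4)nc(Cl)nc32)cc1` gives 35.8%. Compound 4 `Nc1ccccc1NC(=O)c1ccc(Cn2cnc3c(Nc4cccc(Cl)c4)nc(Cl)nc32)cc1` differs from compound 3 by one change, (3-chlorophenyl in place of benzyl on a nitrogen on an aromatic ring). Going by the values given here, the one measured step that bears on this ran the other way: a number 68.7 percentage points lower from compound 1 to compound 3 (beyond the scatter), a large loss when an aromatic group on that nitrogen was exchanged for benzyl. Compound 2, which also carries 3-chlorophenyl on that nitrogen, sits well above compound 3. Returning an aromatic group to that nitrogen is therefore expected to bring a large gain, a number 50.5 percentage points higher from compound 3 to compound 4 (beyond the scatter). Compound 4 is expected to give 58%, within 30% to 82%.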

Compound 4, a percentage reported as inhibition, at one concentration (the size of the read-out at that concentration, not a potency): 29.9%
The estimate for compound 4 lay 28.1 percentage points above the measured number; measured number outside the range, below it.
By their numbers in this assay, from the lowest: compound 3; then compounds 4 and 2 (each within the scatter of the next); then compound 1.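

In this assay, an aromatic group on that nitrogen proves insufficient on its own: a number 22.4 percentage points higher from compound 3 to compound 4 (beyond the scatter) recovers only part of the loss, and a number 46.3 percentage points lower from compound 1 to compound 4 (beyond the scatter) sets 3-chlorophenyl well short of 4-methylphenyl. Removing the ethenyl unit changes little, a number 5.9 percentage points lower from compound 2 to compound 4 (within the scatter), so compound 2 and compound 4 cannot be told apart. Nothing available accounts for the gap between the two aromatic groups. Still open, from the compounds shown here alone, is whether 3-methylphenyl or 4-chlorophenyl would side with compound 1 or compound 4, which would separate the effect of the methyl group from that of its place on the ring.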